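From ethoxy to hydroxy: an expected drop in lipophilicity

The source may report more compounds than this note shows. Statements on the series, on what has been measured and on what is new or still open speak of the compounds shown alone.

Compound 1 `CCOc1ccccc1/C=C/c1ccc2cccc(O)c2n1` gives 4.55 in a physicochemical assay for lipophilicity, read by HPLC; on this read-out higher numbers stand for higher lipophilicity and lower numbers for lower lipophilicity. That is the lower of the two numbers here; compound 2 `Oc1c(Cl)cc(Cl)c2ccc(/C=C/c3ccccc3Cl)nc12` gives 6.02 in this assay, a gap beyond the usual scatter. Compound 3 `Oc1ccccc1/C=C/c1ccc2cccc(O)c2n1` differs from compound 1 in one place: hydrogen in place of ethyl on an oxygen on an aromatic ring. Among the measured compounds shown here, no measured pair shows this change. Compound 3 is expected to sit below compound 1 in this assay by a step beyond the scatter. The expected step is a number 0.85 log units lower from compound 1 to compound 3 (beyond the scatter). Compound 3 is estimated at 3.7, within a range from 3.1 to 4.3.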

Compound 3, partition coefficient: 3.95
The estimate for compound 3 lay 0.25 log units below the measured number; low and high end bracket the measured number.
By their numbers in this assay, from the lowest: compound 3; then compound 1; then compound 2.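

On the oxygen on an aromatic ring, hydrogen in place of ethyl gives a number 0.60 log units lower from compound 1 to compound 3 (beyond the scatter) in this assay. This is the first pair shown that differs in one place, so this change now has a measured size, though it rests on this single pair. Nothing measured here explains why the number moves this way.

From the compounds shown here alone, whether a methyl or a longer chain such as propyl on this oxygen would fall between or beyond these two numbers stays open. So does the effect of an amine in place of the oxygen.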